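Amiloride-type series: tert-butylamino to anilino replacement

The source may report more compounds than this note shows. Statements on the series, on what has been measured and on what is new or still open speak of the compounds shown alone.

Measured so far:
- compound 1, `NC(N)=NC(=O)c1nc(Cl)c(NCc2ccccc2Cl)nc1N`: 90%
- compound 2, `NC(N)=NC(=O)c1nc(Cl)c(NCc2ccc3ccccc3c2)nc1N`: 93%
- compound 3, `CC(C)(C)Nc1nc(N)c(C(=O)N=C(N)N)nc1Cl`: 48%

All three share one core and differ only in the group on the ring nitrogen. In an assay for inhibition of acid-sensing ion channel 3 (Homo sapiens), read by patch clamp, tested at 20 uM (a lower number here means less inhibition, a higher number more inhibition at the concentration tested (going by the name of the read-out)), compound 1 gives 90% and compound 2 gives 93%; these two numbers lie within the usual scatter of each other, so no order between them is claimed. Compound 3, with a tert-butyl on that nitrogen, gives 48% in this assay. That is the lowest of the three numbers, and its distance to compound 1 and to compound 2 is beyond the scatter in both cases. Both of the higher numbers belong to compounds whose substituent carries an aromatic ring; compound 3 carries none.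

Compound 4, `NC(N)=NC(=O)c1nc(Cl)c(Nc2ccccc2)nc1N`, has not been measured. Relative to compound 3 the difference is phenyl in place of tert-butyl on a nitrogen on an aromatic ring. Within the data shown here, no measured pair shows exactly this step, so its size can only be estimated from the three numbers above. Compound 4 is expected to move upward from compound 3, by a number 24 percentage points higher from compound 3 to compound 4 (beyond the scatter), a step expected to be beyond the scatter. For compound 4 the estimate in this assay is 72%, within a range from 48% to 90%.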

Compound 4, a percentage reported as inhibition, at one concentration (the size of the read-out at that concentration, not a potency): 95%
For compound 4 the middle estimate is 23 percentage points below the measured one; the whole stated range lies below it.
By their numbers in this assay, from the lowest: compound 3; then compounds 1, 2 and 4 (each within the scatter of the next).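

In this assay, among these compounds, the change from tert-butyl to phenyl on a nitrogen on an aromatic ring gives a number 47 percentage points higher from compound 3 to compound 4 (beyond the scatter) and is the first step that isolates this position. It also shows that the aromatic ring need not be held away from that nitrogen by a carbon link: compound 4, which has no such link, gives 95% and lies within the scatter of compound 1 at 90% and compound 2 at 93% in this assay, so the link makes no visible difference among these three. Nothing at hand accounts for the size of the step from tert-butyl to phenyl.

Still open, going by these compounds, is whether the gain needs an aromatic ring at all, since a cyclohexyl group or a straight butyl chain on the same nitrogen would separate the ring from the mere loss of tert-butyl, and whether a phenyl carrying a carboxylic acid or an amine holds the same level. Readings at a single concentration also give no potency order among compound 1, compound 2 and compound 4.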